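Compound 2 to compound 4: oxetan-3-yl replaced by pyrimidin-4-yl

A few compounds are considered here, and "the series" means these few. Any claim that something is new, unique, unknown or untested is made for them only; others in the source may bear on it.

Values in an ADME assay on MT4 cells (Homo sapiens) for cytotoxicity, with a stated time of 5 days (on this read-out higher numbers stand for lower toxicity in this test and lower numbers for higher toxicity in this test), follow, each one a limit and not a number:
compound 1 `CC(C)N(c1cc(C#CC(C)(C)C)sc1C(=O)O)C(=O)[C@H]1CC[C@H](C)CC1` gives > 20000 nM as a limit
compound 2 `CC(C)(C)C#Cc1cc(N(C(=O)[C@H]2CC[C@H](C)CC2)[C@H]2CC[C@H](OC3COC3)CC2)c(C(=O)O)s1` gives > 20000 nM as a limit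
compound 3 `CON=C1CCC(N(c2cc(C#CC(C)(C)C)sc2C(=O)O)C(=O)[C@H]2CC[C@H](C)CC2)CC1` gives > 20000 nM as a limit

In this assay compound 2 has only the limit > 20000 nM and no number. All three measured compounds sit at one place (the limit of > 20000 nM in this assay, at which 3 of the 3 values shown sit) and none of them can be ranked.

Compound 4 `CC(C)(C)C#Cc1cc(N(C(=O)[C@H]2CC[C@H](C)CC2)[C@H]2CC[C@H](Oc3ccncn3)CC2)c(C(=O)O)s1` differs from compound 2 at one place (pyrimidin-4-yl in place of oxetan-3-yl on an oxygen on a saturated carbon), with pyrimidin-4-yl in place of oxetan-3-yl on an oxygen on a saturated carbon.

Going by the values given here, with a step that the two limits leave unreadable from compound 1 to compound 2 and a step that the two limits leave unreadable from compound 2 to compound 3 and also a step that the two limits leave unreadable from compound 1 to compound 3 as the only measured steps, all on the amide-type nitrogen and none on the oxygen changed here, no readable size carries over. The expected step is a number no higher from compound 2 to compound 4 (the limit leaves the size open) with no direction favoured and nothing expected beyond the scatter, and a report at the limit of this assay is the likeliest outcome. The estimated value of compound 4 is 20000 nM within an expected range of 8000 nM to 40000 nM for this estimate.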

Compound 4, half-maximal cytotoxic concentration: > 20000 nM
Compound 4: only a limit was reported; the forecaster's own chance of this, stated with the estimate: 80%; the middle value sits exactly at the limit.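

In this assay compound 4 gives > 20000 nM, a limit and not a number. The step between compound 2 and compound 4 therefore cannot be read: the limit of > 20000 nM in this assay, at which 4 of the 4 values shown sit.

The compounds shown leave open how far the values of compound 1, compound 2, compound 3 and compound 4 lie from one another in this assay, and whether pyrimidin-4-yl and oxetan-3-yl differ at all on this read-out.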